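Phenyl in place of propyl on the shared core

A few compounds are considered here, and "the series" means these few. Any claim that something is new, unique, unknown or untested is made for them only; others in the source may bear on it.

compound 1 `Cn1nc(C(F)(F)F)c2c(-c3ccccc3)cc(NNC(=O)Nc3cc(Cl)nc(Cl)c3)nc21`: 13100 nM
compound 2 `Cc1nn(C)c2nc(NNC(=O)Nc3cc(Cl)nc(Cl)c3)cc(-c3ccc(F)cc3)c12`: 17400 nM
compound 3 `CCCc1cc(NNC(=O)Nc2cc(Cl)nc(Cl)c2)nc2c1c(C)nn2C`: 40800 nM

The three measured compounds share one core and differ in the group on one aromatic carbon of that core and in a small group elsewhere. In a functional assay on SW620/5-FU cells (Homo sapiens) for cytotoxicity, read by MTT assay, with a stated time of 48 h, in the presence of a further agent that is not named here (on this read-out higher numbers stand for an effect only at larger amounts of compound and lower numbers for an effect already at smaller amounts), compound 3 gives 40800 nM, the highest of the three numbers; compound 2 gives 17400 nM, and compound 1 gives 13100 nM. Going by the values given here, the one measured step here is a 2.3-fold higher number from compound 2 to compound 3 (0.37 log units; beyond the scatter).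

Compound 4 `Cc1nn(C)c2nc(NNC(=O)Nc3cc(Cl)nc(Cl)c3)cc(-c3ccccc3)c12` differs from compound 3 by phenyl in place of propyl on an aromatic carbon. This change is close to the reverse of the measured step, the entering ring now lacking the fluorine that the ring of compound 2 carries. Compound 1 also bears a phenyl at this place, with a different small group elsewhere on the core, and its number in this assay is near that of compound 2. A modest fall is therefore expected, undoing the step from compound 2 to compound 3: for compound 4 the expected step is a 2.6-fold lower number from compound 3 to compound 4 (0.41 log units; beyond the scatter). Compound 4 is estimated at 16000 nM, within a range of 8000 nM to 32000 nM.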

Compound 4, half-maximal effective concentration: 22900 nM
Beside the measured number, compound 4's estimate is 1.4-fold (0.16 log units) below it; low and high end bracket the measured number.
By their numbers in this assay, from the lowest: compounds 1, 2, 4 and 3 (each within the scatter of the next, the first and the last beyond it).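

In this assay the change from propyl to phenyl on this aromatic carbon gives a 1.8-fold lower number from compound 3 to compound 4 (0.25 log units; within the scatter) and so stays inside the usual spread, unlike the 4-fluorophenyl step, a 2.3-fold higher number from compound 2 to compound 3 (0.37 log units; beyond the scatter) in the opposite sense. Taking away the fluoro gives a 1.3-fold higher number from compound 2 to compound 4 (0.12 log units; within the scatter) and methyl in place of trifluoromethyl gives a 1.7-fold higher number from compound 1 to compound 4 (0.24 log units; within the scatter), so neither single change separates its pair of compounds on this read-out. Nothing measured here speaks to the reason for these steps.

On these data alone, what an amine or a carboxylic acid at this place would do remains open, as does the effect of a chain longer than propyl. A methoxy group on the phenyl ring is likewise untested among the compounds shown.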